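The source may hold more compounds than are shown below. What is called first, only, known or untested is meant among the compounds shown, and "the series" means these compounds.

Compound 1 `CCC(=O)NCCCCc1ccccc1OC` is the starting point; in an assay for binding affinity to melatonin receptor (Gallus gallus) (on this read-out higher numbers stand for weaker inhibition and lower numbers for stronger inhibition), compound 1 gives 339 nM. Compound 2 `CCCC(=O)NCCCCc1ccccc1OC` carries methyl in place of hydrogen on a saturated chain carbon, two bonds along the chain from a carbonyl carbon relative to compound 1, and in this assay compound 2 gives 116 nM, which amounts to a 2.9-fold lower number from compound 1 to compound 2 (0.47 log units; beyond the scatter). Compound 3 `CCC(=O)NCCCCc1ccc(OC)cc1` has the same atoms as compound 1 joined differently; the difference between the two cores is not broken down here. In this assay compound 3 gives 1400 nM, the highest number of the three measured compounds, with compound 1 nearest to it and compound 2 furthest away. Compound 4 `CCCC(=O)NCCCCc1ccc(OC)cc1` is not yet measured and stands to compound 3 as compound 2 stands to compound 1: it carries methyl in place of hydrogen on a saturated chain carbon, two bonds along the chain from a carbonyl carbon, the same change at the same place. Going by the values given here, only one step of this kind has been seen, so the expectation for compound 4 rests on a single pair. Compound 4 is expected to show a 2.8-fold lower number from compound 3 to compound 4 (0.45 log units; beyond the scatter) because a 2.9-fold lower number from compound 1 to compound 2 (0.47 log units; beyond the scatter) was observed on the other core. Compound 4 is therefore estimated at 500 nM, with a range from 200 nM to 1200 nM.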

Compound 4, inhibition constant: 822 nM
Beside the measured number, compound 4's estimate is 1.6-fold (0.22 log units) below it; the measured number falls inside the stated range.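

In this assay the methyl in place of hydrogen on a saturated chain carbon, two bonds along the chain from a carbonyl carbon, gives a 1.7-fold lower number from compound 3 to compound 4 (0.23 log units; within the scatter) on the core of compound 3, so on this core the step alone cannot be told apart from repeat scatter. Set beside the earlier step, it does not differ from it by more than that scatter: the same change on two cores in this assay, a 2.9-fold lower number (0.47 log units; beyond the scatter) from compound 1 to compound 2 and a 1.7-fold lower number (0.23 log units; within the scatter) from compound 3 to compound 4, 1.7-fold (0.23 log units) apart, within the scatter of two such steps. This is consistent with the change carrying over between these two cores, but with one pair on each core it does not show that the step is equal on both, and it says nothing about any other core.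

The compounds shown leave open whether a chain longer than propylcarbonyl, or a cyclopropyl group in its place, would extend the same step on either core. They also leave open how a hydroxyl group in place of the methoxy group would read on either core.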